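Aryl variation on the shared core

The source may report more compounds than this note shows. Statements on the series, on what has been measured and on what is new or still open speak of the compounds shown alone.

Compound 1 `CC(=O)Nc1cccc(C2CCN(CCCn3c(-c4ccccc4C(F)(F)F)nc4ccccc43)CC2)c1`: 50 nM
Compound 2 `COc1ccccc1-c1nc2ccccc2n1CCCN1CCC(c2cccc(NC(C)=O)c2)CC1`: 747 nM
Compound 3 `CC(=O)Nc1cccc(C2CCN(CCCn3c(-c4ccc(Br)cc4)nc4ccccc43)CC2)c1`: 5 nM

All numbers come from an assay for displacement of a labelled ligand from melanin-concentrating hormone receptor 1 (Homo sapiens), read by fluorescence; a higher number here means a weaker inhibitor, a lower number a stronger inhibitor. Compound 3 gives the lowest number of the three; the nearest step to it is a 10-fold lower number from compound 1 to compound 3 (1.00 log units; beyond the scatter) and the furthest is a 150-fold lower number from compound 2 to compound 3 (2.17 log units; beyond the scatter).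

Compound 4 `CC(=O)Nc1cccc(C2CCN(CCCn3c(-c4ccc(Cl)c(Cl)c4)nc4ccccc43)CC2)c1` carries the change (3,4-dichlorophenyl in place of 4-bromophenyl on an aromatic carbon). Both measured steps into compound 3 exchanged the whole aryl group and moved the number beyond the scatter, so this position matters. Compound 4, however, keeps a halogen on that ring and adds a second chlorine only. A step within the scatter, or a small one in either direction, is therefore expected: no change at the digits printed from compound 3 to compound 4 (within the scatter). For compound 4 the estimated value is 5 nM, with a range of 2 nM to 15 nM.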

Compound 4, half-maximal inhibitory concentration: 24 nM
Estimate against measurement, compound 4: 4.8-fold (0.68 log units) below, outside the stated range (above it).
By their numbers in this assay, from the lowest: compound 3; then compound 4; then compound 1; then compound 2.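

Two halogen-bearing phenyl groups are not interchangeable at this position: a 4.8-fold higher number from compound 3 to compound 4 (0.68 log units; beyond the scatter) in this assay, so the position responds to changes smaller than a full exchange of aryl type. Against the other two aryl groups, a 31-fold lower number from compound 2 to compound 4 (1.49 log units; beyond the scatter), while a 2.1-fold lower number from compound 1 to compound 4 (0.32 log units; beyond the scatter), which places 3,4-dichlorophenyl much nearer 2-(trifluoromethyl)phenyl than 2-methoxyphenyl. Nothing available explains these steps.

The change from compound 3 to compound 4 alters both the identity and the count of the halogens, and the shown compounds cannot separate the two. A 4-chlorophenyl group at this position would address that question.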